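The source may hold more compounds than are shown below. What is called first, only, known or untested is meant among the compounds shown, and "the series" means these compounds.

Compound 3 `COc1ccc(S(=O)(=O)c2cnc3ccc(C)cc3c2N2CCC(C)CC2)cc1Cl` gives 93% in an assay on isolated protein for displacement of a labelled ligand from metabotropic glutamate receptor 5 (Homo sapiens), with a stated time of 60 min, tested at 1 uM (on this read-out lower numbers stand for less inhibition and higher numbers for more inhibition at the one concentration tested (going by the name of the read-out)), the largest of the three numbers shown, although compound 2 `Cc1ccc2ncc(S(=O)(=O)c3ccc(C)c(F)c3)c(N3CCC(C)CC3)c2c1` with 91% and compound 1 `Cc1ccc2ncc(S(=O)(=O)c3ccc(F)cc3)c(N3CCC(C)CC3)c2c1` with 90% both lie within the usual scatter of it. Swapping the aryl group on the sulfonyl sulfur has so far changed little: a number 1 percentage points higher from compound 1 to compound 2 (within the scatter), a number 3 percentage points higher from compound 1 to compound 3 (within the scatter) and a number 2 percentage points higher from compound 2 to compound 3 (within the scatter). Compound 4 `COc1cccc(S(=O)(=O)c2cnc3ccc(C)cc3c2N2CCC(C)CC2)c1` differs from compound 3 by 3-methoxyphenyl in place of 3-chloro-4-methoxyphenyl on a sulfonyl sulfur, again an exchange on that same sulfonyl sulfur. All three earlier exchanges stayed within scatter, so the step expected here is a number 3 percentage points lower from compound 3 to compound 4 (within the scatter), no real change in this assay. Compound 4 is therefore estimated at 90%, with a likely range from 80% to 97%.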

Compound 4, a percentage reported as inhibition, at one concentration (the size of the read-out at that concentration, not a potency): 96%
Compound 4: middle estimate off by 6 percentage points, on the low side; the measured number falls inside the stated range.
By their numbers in this assay, from the lowest: compounds 1, 2, 3 and 4 (each within the scatter of the next).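

In this assay, 3-methoxyphenyl in place of 3-chloro-4-methoxyphenyl gives a number 3 percentage points higher from compound 3 to compound 4 (within the scatter), so the chlorine is not needed to keep the read-out high in this series. The same group gives a number 5 percentage points higher from compound 2 to compound 4 (within the scatter) and a number 6 percentage points higher from compound 1 to compound 4 (within the scatter), so even the widest gaps among these sulfonyl aryl groups show no real change. No measurement shown gives a reason for these level numbers. Still open, from the compounds shown here alone, is whether the number in this assay stays level with a ring bearing an amine or a carboxylic acid, or a plain butyl chain instead of an aryl ring, on the sulfonyl sulfur. A single-concentration read-out also leaves any potency ranking of these four compounds unsettled.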